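Selenoether series on a colon carcinoma line: chain length notes

A few compounds are considered here, and "the series" means these few. Any claim that something is new, unique, unknown or untested is made for them only; others in the source may bear on it.

Measured compounds, in a functional assay on HT-29 cells (Homo sapiens) for cytotoxicity, read by MTT assay, with a stated time of 72 h; a higher number here means a weaker inhibitor of growth, a lower number a stronger inhibitor of growth:
compound 1, `CCCCC[Se]c1nc(NCc2ccccc2)c2ccccc2n1`: compound 1 gives 72700 nM
compound 2, `CCCCC[Se]c1nc(N)c2cccnc2n1`: compound 2 gives 5910 nM
compound 3, `C[Se]c1nc(NCc2ccccc2)c2ccccc2n1`: compound 3 gives 42800 nM

Compound 1 and compound 3 share a core and differ in one place only; the change is hydrogen in place of butyl on a saturated chain carbon bound to a selenium atom. In this assay this change made the step of a 1.7-fold lower number from compound 1 to compound 3 (0.23 log units; within the scatter), so the two values do not separate.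

Compound 2 stands on a different core. How the core of compound 2 differs from the core of compound 1 is not broken down here. In this assay compound 2 gives the lowest of the three numbers, and its steps to compound 3 and to compound 1 are both beyond the scatter.

Compound 4, `C[Se]c1nc(N)c2cccnc2n1`, is not yet measured. It relates to compound 2 as compound 3 relates to compound 1: the change is hydrogen in place of butyl on a saturated chain carbon bound to a selenium atom, at the same place as before, so it is the same change, seen for the second time in this set.

Expectation for compound 4 in this assay: the step is estimated as a 1.5-fold lower number from compound 2 to compound 4 (0.17 log units; within the scatter), because the one earlier instance of this change gave a 1.7-fold lower number from compound 1 to compound 3 (0.23 log units; within the scatter), a step inside the scatter. The value of compound 4 is therefore expected to lie close to that of compound 2, estimated at 4000 nM with a likely range from 1500 nM to 11000 nM.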

Compound 4, concentration for 50% growth inhibition: 44100 nM
Estimate against measurement, compound 4: 11-fold (1.04 log units) below, outside the stated range (above it).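

In this assay the change of pentyl to methyl gives a 7.5-fold higher number from compound 2 to compound 4 (0.87 log units; beyond the scatter) and so does not act alike on the two cores, the step on the core of compound 1 being one that does not separate its two compounds, as the two steps set side by side show: the same change on two cores in this assay, a 1.7-fold lower number (0.23 log units; within the scatter) from compound 1 to compound 3 and a 7.5-fold higher number (0.87 log units; beyond the scatter) from compound 2 to compound 4, 13-fold (1.10 log units) apart, beyond the scatter of two such steps. Within these two pairs, then, the effect of shortening the chain depends on the core it sits on, and a step read on one core is no guide to the size or even the direction of the step on the other. This rests on one pair per core and does not show which part of the core difference is responsible, nor why pentyl goes with the lower number on the core of compound 2 alone.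

Still open, from the compounds shown here alone, is how the number moves along the chain on either core, with ethyl or propyl as intermediate lengths and hexyl or octyl as longer chains. Also open, going by these compounds, is whether the dependence on the core persists when a sulfur atom takes the place of selenium, as in the matching thioethers.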